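The source may hold more compounds than are shown below. What is called first, only, known or untested is meant among the compounds shown, and "the series" means these compounds.

Of the compounds shown here, three built on one shared core have been tested in a functional assay (aorta) for antagonist activity, with Oryctolagus cuniculus as the target; on this read-out higher numbers stand for weaker inhibition and lower numbers for stronger inhibition. Compound 1 `CCCCc1ccc(CNC(=O)NC2CCCCC2)c(=O)n1Cc1ccc(-c2ccccc2-c2nn[nH]n2)cc1` gives 90 nM, compound 2 `CCCCc1ccc(CN(Cc2ccccc2)C(C)=O)c(=O)n1Cc1ccc(-c2ccccc2-c2nn[nH]n2)cc1` gives 1 nM, and compound 3 `CCCCc1ccc(CN(Cc2ccccc2)S(=O)(=O)c2ccccc2)c(=O)n1Cc1ccc(-c2ccccc2-c2nn[nH]n2)cc1` gives 20 nM. Both changes between them were large: a 90-fold lower number from compound 1 to compound 2 (1.95 log units; beyond the scatter), and a 20-fold higher number from compound 2 to compound 3 (1.30 log units; beyond the scatter). Compound 3 thus stands second highest of the three numbers, well below compound 1 and far above compound 2.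

Compound 4 `CCCCc1ccc(CN(Cc2ccccc2)S(C)(=O)=O)c(=O)n1Cc1ccc(-c2ccccc2-c2nn[nH]n2)cc1` differs from compound 3 by methyl in place of phenyl on a sulfonyl sulfur. The step most relevant here is the one in which acetyl became phenylsulfonyl and the number rose sharply, that is a 20-fold higher number from compound 2 to compound 3 (1.30 log units; beyond the scatter). Among the compounds with values here, compound 4 keeps the sulfonyl but carries the smallest possible group on it, so the number is expected to move back down, though by less than that earlier step, given that no compound shows a methylsulfonyl directly. For compound 4 in this assay the expected value is 8 nM, within a range of 2 nM to 30 nM, which would mean an expected step of a 2.5-fold lower number from compound 3 to compound 4 (0.40 log units; beyond the scatter).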

Compound 4, half-maximal inhibitory concentration: 2 nM
Compound 4: middle estimate off by 4.0-fold (0.60 log units), on the high side; the range from low to high includes it.
By their numbers in this assay, from the lowest: compounds 2 and 4 (each within the scatter of the next); then compound 3; then compound 1.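

In this assay the group on the sulfonyl sulfur clearly matters: methyl in place of phenyl gives a step of its own (a 10-fold lower number from compound 3 to compound 4 (1.00 log units; beyond the scatter)), so a sulfonyl on this amine nitrogen does not by itself bring the higher number. Methylsulfonyl and acetyl on that nitrogen cannot be told apart (a 2.0-fold higher number from compound 2 to compound 4 (0.30 log units; within the scatter)), while benzyl(methylsulfonyl)amino in place of (cyclohexylcarbamoyl)amino gives a large drop (a 45-fold lower number from compound 1 to compound 4 (1.65 log units; beyond the scatter)). Nothing available explains why these groups behave this way.

Still open, going by these compounds, is whether an ethyl or a longer chain on the sulfonyl sulfur would read like compound 4 or like compound 3. Also open, on these data alone, is whether the benzyl on the amine nitrogen could be exchanged for a plain methyl while keeping the methylsulfonyl.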